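Working notes on the amine substituent change toward compound 3

A few compounds are considered here, and "the series" means these few. Any claim that something is new, unique, unknown or untested is made for them only; others in the source may bear on it.

Measured so far:
compound 1, `COc1ccc(CN(Cc2ccccc2)Cc2c(O)ccc3c(=O)cc(C)oc23)cc1`, gives 42.7 ug/mL in a functional assay on KB cells (Homo sapiens) for inhibition, read by sulforhodamine B assay, with a stated time of 72 h; on this read-out lower numbers stand for stronger inhibition and higher numbers for weaker inhibition.
compound 2, `CCN(Cc1ccc(OC)cc1)Cc1c(O)ccc2c(=O)cc(C)oc12`, gives 47.4 ug/mL in this assay.

Compound 2 stands at the highest of the two numbers, but its nearest neighbour, compound 1, sits within the scatter of it: the step of a 1.1-fold higher number from compound 1 to compound 2 (0.05 log units; within the scatter) shows no difference beyond repeat variation.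

Compound 3, `COc1ccc(CN(Cc2ccc([N+](=O)[O-])cc2)Cc2c(O)ccc3c(=O)cc(C)oc23)cc1`, is unmeasured. It differs from compound 2 by 4-nitrophenyl in place of methyl on a saturated chain carbon bound to an amine nitrogen. For the measured compounds named here, the one measured step that bears on this is a 1.1-fold higher number from compound 1 to compound 2 (0.05 log units; within the scatter), where an aryl group on the same saturated chain carbon was exchanged for methyl with no effect beyond the scatter. Compound 3 now goes the other way, methyl to 4-nitrophenyl, and on that single precedent a step within the scatter is expected, a 1.2-fold lower number from compound 2 to compound 3 (0.07 log units; within the scatter). Compound 3 is therefore estimated at 40 ug/mL in this assay, with a range from 18 ug/mL to 85 ug/mL.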

Compound 3, half-maximal inhibitory concentration: 24.4 ug/mL
Estimate against measurement, compound 3: 1.6-fold (0.21 log units) above; the measured number falls inside the stated range.
By their numbers in this assay, from the lowest: compounds 3, 1 and 2 (each within the scatter of the next).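

Even the larger exchange at this saturated chain carbon, a single methyl replaced by 4-nitrophenyl with its six-membered aromatic ring, stays within the scatter in this assay (a 1.9-fold lower number from compound 2 to compound 3 (0.29 log units; within the scatter)). Nitro in place of hydrogen on an aromatic carbon, the first substitution on this aryl group, also stays within the scatter (a 1.8-fold lower number from compound 1 to compound 3 (0.24 log units; within the scatter)). No measurement here bears on why these numbers fall as they do.

No step among the compounds shown lies beyond the scatter, so it remains open whether any change at this place can separate compounds in this assay. An amine, a carboxylic acid or a longer chain at this saturated chain carbon, or a methoxy group in place of the nitro, remains to be judged.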